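The compounds below may be only part of what the source reports. "The series", "measured", "known", "first", "only" and "open" are said of these compounds alone.

Measured compounds in a functional assay on MDA-MB-231 cells (Homo sapiens) for cytotoxicity, read by MTT assay, with a stated time of 48 h; on this read-out higher numbers stand for weaker inhibition and lower numbers for stronger inhibition:
compound 1 `Fc1cccc(-c2nc(Nc3ccccc3)c3ccccc3n2)c1`: > 50000 nM
compound 2 `Fc1ccc2nc(-c3ccccc3)nc(Nc3ccccc3)c2c1`: > 50000 nM
compound 3 `Fc1ccc(Nc2nc(-c3cccc(F)c3)nc3ccc(F)cc23)cc1`: > 50000 nM

Each of these values is a limit of this assay, not a number. Compound 3 therefore stands nowhere in particular on the numbers shown: its value is a limit, and the two other values are limits as well (the limit of > 50000 nM in this assay, at which 3 of the 3 values shown sit), so no measured step separates any pair of these compounds.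

Compound 4 `Fc1cccc(-c2nc(Nc3ccccc3Cl)c3cc(F)ccc3n2)c1` has not been measured. It differs from compound 3 by 2-chlorophenyl in place of 4-fluorophenyl on a nitrogen on an aromatic ring. Within the data shown here, with no measured step to lean on, the step from compound 3 to compound 4 is expected to be none beyond the scatter, as a step that the limit leaves unreadable from compound 3 to compound 4 expresses. Compound 4 is estimated at 60000 nM, within 20000 nM to 200000 nM.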

Compound 4, half-maximal inhibitory concentration: > 50000 nM
Compound 4 gave a limit, no number; the forecaster's own chance of this, stated with the estimate: 75%; the middle value is on the limit's open side.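

Among these compounds, compound 4, like compound 3, gave only a limit, so no step between these two compounds can be read. The compounds shown leave open whether any change to the shared core would give a measurable value, as every result is a limit: the limit of > 50000 nM in this assay, at which 4 of the 4 values shown sit.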